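Fluorophenyl Swap in a Series Stuck at the Limit

The compounds below may be only part of what the source reports. "The series", "measured", "known", "first", "only" and "open" are said of these compounds alone.

Three compounds share one core and differ only in the aryl group on an amine nitrogen in a ring: compound 1 `O=C(CN1CCN(c2cccc(F)c2)CC1)Nc1nc2c(s1)CCCC2`, compound 2 `Cc1ccc(N2CCN(CC(=O)Nc3nc4c(s3)CCCC4)CC2)cc1` and compound 3 `O=C(CN1CCN(c2cccnc2)CC1)Nc1nc2c(s1)CCCC2`. In an assay on isolated protein for inhibition of long-chain fatty acid transport protein 1 (Mus musculus), read by scintillation counting, with a stated time of 20 min (a lower number here means a stronger inhibitor, a higher number a weaker inhibitor), compound 1 gives > 10000 nM, a limit of the assay rather than a number. In this assay compound 2 gives > 10000 nM, again only a limit. In this assay compound 3 gives > 10000 nM, also a limit. Compound 3 thus stands at the limit with the other two, and the steps a step that the two limits leave unreadable from compound 1 to compound 2, a step that the two limits leave unreadable from compound 1 to compound 3 and a step that the two limits leave unreadable from compound 2 to compound 3 cannot be sized. What the series shows is summarised by the limit of > 10000 nM in this assay, at which 3 of the 3 values shown sit.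

Compound 4 `O=C(CN1CCN(c2ccc(F)cc2)CC1)Nc1nc2c(s1)CCCC2` carries the change (4-fluorophenyl in place of pyridin-3-yl on an amine nitrogen in a ring). Among the measured compounds shown here, no measured step bears readably on it, since each lies between two limits. Compound 1, with 3-fluorophenyl in the same place, also sits at the limit. Compound 4 is therefore expected to remain at or beyond the limit, so that a step that the limit leaves unreadable from compound 3 to compound 4 is expected to be no readable step. The estimate for compound 4 is 15000 nM, in the range 5000 nM to 50000 nM.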

Compound 4, half-maximal inhibitory concentration: 4000 nM
Compound 4: the middle estimate sits 3.8-fold (0.57 log units) above what was measured, outside the stated range (below it).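

In this assay, the 4-fluorophenyl group on the amine nitrogen in a ring gives the only readable value among the compounds shown, with an at least 2.5-fold lower number from compound 3 to compound 4 (0.39 log units; beyond the scatter). The placing of the fluoro group on the aryl ring matters here, with an at least 2.5-fold lower number from compound 1 to compound 4 (0.39 log units; beyond the scatter), and so does the group on that aromatic carbon, with an at least 2.5-fold lower number from compound 2 to compound 4 (0.39 log units; beyond the scatter). This single change stands alone, as the rest of the series has yet to yield a number: the limit of > 10000 nM in this assay, at which 3 of the 4 values shown sit.

As far as these compounds go, the steps among compound 1, compound 2 and compound 3 cannot be read, and the full size of each new step stays unknown, since one end of each is a limit. From the compounds shown here alone, whether a 4-chlorophenyl or 4-cyanophenyl group at the same place would match, exceed or lose the value of compound 4 remains open.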